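Removing one methoxy from compound 2

The source may hold more compounds than are shown below. What is called first, only, known or untested is meant among the compounds shown, and "the series" means these compounds.

Compound 2 `COc1ccc(/C=C2\CCN=C2c2cccnc2)c(OC)c1` gives 4550 nM in an assay for displacement of a labelled ligand from Nicotinic acetylcholine receptor alpha8 subunit (Periplaneta americana), read by scintillation counting, with a stated time of 2 h, at 24 degrees C (a higher number here means a weaker inhibitor, a lower number a stronger inhibitor), while compound 1 `Oc1ccccc1/C=C1\CCN=C1c1cccnc1` gives 6900 nM in this assay; these two values lie within the scatter of each other, so neither compound stands apart. Compound 3 `COc1ccccc1/C=C1\CCN=C1c1cccnc1` differs from compound 2 by hydrogen in place of methoxy on an aromatic carbon. Among the measured compounds shown here, no step between measured compounds covers this change, so a step no larger than the scatter is expected, in either direction, as a 1.2-fold higher number from compound 2 to compound 3 (0.08 log units; within the scatter). Compound 3 is expected to give 5500 nM in this assay, with a range from 2500 nM to 12000 nM.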

Compound 3, half-maximal inhibitory concentration: > 10000 nM
Compound 3 gave a limit, no number; the forecaster's own chance of this, stated with the estimate: 5%; middle value at least 1.8-fold (0.25 log units) away from the limit.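

Compound 3 carries a limit and not a number: the limit of > 10000 nM in this assay, at which 1 of the 3 values shown sits.

Even so, hydrogen in place of the methoxy para to a large group gives an at least 2.1-fold higher number from compound 2 to compound 3 (0.34 log units; beyond the scatter) in this assay, so this position is not indifferent to the change. Methyl in place of hydrogen on the oxygen on the aromatic ring gives an at least 1.4-fold higher number from compound 1 to compound 3 (0.16 log units; that floor lies within the scatter), and that floor does not separate these two compounds.

From the compounds shown here alone, what an amine or a chlorine at this position would give stays open. Going by these compounds, the actual distance of compound 3 from compound 2 also stays open.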